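Swapping an Aryl Group on a Ring Amine Nitrogen

This account rests on a few compounds, and the source may have more. Where it says the series, first, only, none or still open, it means among the compounds named here.

Measured so far:
compound 1 `S=c1oc(-c2ccc3c(c2)OCCO3)nn1CN1CCN(C(c2ccccc2)c2ccccc2)CC1` gives > 50000 nM
compound 2 `Cc1ccc(N2CCN(Cn3nc(-c4ccc5c(c4)OCCO5)oc3=S)CC2)c(C)c1` gives > 50000 nM

Both values come from a functional assay on HeLa cells (Homo sapiens) for antiproliferative activity, read by MTT assay, with a stated time of 48 h; a higher number here means a weaker inhibitor, a lower number a stronger inhibitor. The result for compound 1 is a limit of that assay, not a number. The result for compound 2 is likewise a limit and not a number. Among the compounds with values here, compound 2 therefore stands at the edge of what this assay reports, and the only other value shown sits at the same edge (the limit of > 50000 nM in this assay, at which 2 of the 2 values shown sit). Within the data shown here, no step between measured compounds can be stated, since the two compounds differ in more than one place and neither gives a number.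

Compound 3 `Fc1ccccc1N1CCN(Cn2nc(-c3ccc4c(c3)OCCO4)oc2=S)CC1` is not yet measured. It differs from compound 2 by 2-fluorophenyl in place of 2,4-dimethylphenyl on an amine nitrogen in a ring, a 2-fluorophenyl in place of a 2,4-dimethylphenyl on an amine nitrogen in a ring. With no measured step to lean on and both shown values at the limit, no direction beyond the scatter is expected; the most likely outcome is that compound 3 also returns only a limit. Compound 3 is expected to give about 60000 nM in this assay, within 15000 nM to 250000 nM, and the expected step that the limit leaves unreadable from compound 2 to compound 3 is essentially none.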

Compound 3, half-maximal inhibitory concentration: 37300 nM
For compound 3 the middle estimate is 1.6-fold (0.21 log units) above the measured one; measured number inside the range.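

With compound 3, a group on the amine nitrogen in a ring yields a number rather than a limit for the first time among the compounds shown: in this assay compound 3 gives 37300 nM. The change from 2,4-dimethylphenyl to 2-fluorophenyl at this position gives an at least 1.3-fold lower number from compound 2 to compound 3 (0.12 log units; that floor lies within the scatter), so the position can carry a group that returns a readable value, though this floor does not establish a real gain. The true size of the step cannot be read, as the result for compound 2 is a limit of the assay: the limit of > 50000 nM in this assay, at which 2 of the 3 values shown sit.

The compounds shown leave open whether the fluorine or the loss of the two methyl groups accounts for the readable value, a question that a plain phenyl or a chlorophenyl on the same nitrogen would help to settle. Also open, from the compounds shown here alone, is how a methoxy group, an amine or a carboxylic acid on that aromatic ring would read in this assay, and whether any group at this position can give a value well clear of the limit.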